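The source may hold more compounds than are shown below. What is called first, only, known or untested is meant among the compounds shown, and "the series" means these compounds.

Measured in a functional assay on COLO 205 cells (Homo sapiens) for antiproliferative activity, with a stated time of 72 h; a lower number here means a stronger inhibitor, a higher number a weaker inhibitor:
- Compound 1 `C=C1C=CC(=O)[C@@H]2[C@H](Cc3ccc(OCOC)cc3)CC[C@H]12`: 219 nM
- Compound 2 `C=C1C=CC(=O)[C@@H]2[C@H](Cc3ccccc3)CC[C@H]12`: 547 nM
- Compound 3 `C=C1C=CC(=O)[C@@H]2[C@H](Cc3ccc(OC)c(O)c3)CC[C@H]12`: 244 nM

Compound 2 has the highest number of these three, which makes it the weakest inhibitor in this small set. Compound 4 `C=C1C=CC(=O)[C@@H]2[C@H](Cc3ccc(O)cc3)CC[C@H]12` differs from it by one change: hydroxy in place of hydrogen on an aromatic carbon. The closest measured evidence is a 2.5-fold higher number from compound 1 to compound 2 (0.40 log units; beyond the scatter), where hydrogen replaces methoxymethoxy on an aromatic carbon. Read backwards, this suggests that adding an oxygen-linked group to compound 2 may lower the number. Compound 3, which carries hydroxy and methoxy groups, gives 244 nM and points the same way. On these data alone, a modest fall in this assay is therefore expected, although hydroxy itself is untested here. The expected change is a 2.1-fold lower number from compound 2 to compound 4 (0.32 log units; beyond the scatter). For compound 4, the estimated value is 260 nM, with an expected range of 120 nM to 560 nM.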

Compound 4, half-maximal inhibitory concentration: 218 nM
The estimate for compound 4 lay 1.2-fold (0.08 log units) above the measured number, and the stated range covers the measured number.
By their numbers in this assay, from the lowest: compounds 4, 1 and 3 (each within the scatter of the next); then compound 2.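

In this assay, hydroxy in place of hydrogen on the aromatic carbon para to a large group gives a 2.5-fold lower number from compound 2 to compound 4 (0.40 log units; beyond the scatter) and shows that this small group alone is enough for the change. Taking the methoxymethyl off that oxygen gives a 1.0-fold lower number from compound 1 to compound 4 (0.00 log units; within the scatter) and shows that this read-out does not separate the free hydroxy from its capped form. Nothing measured here explains this result.

The compounds shown leave open whether an amine or a fluorine on this aromatic carbon would act like hydroxy. They also leave open how a longer chain on the oxygen would fare.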